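Swapping a Selenium Side Chain for a Protected Amino Acid

The source may hold more compounds than are shown below. What is called first, only, known or untested is meant among the compounds shown, and "the series" means these compounds.

Measured compounds:
compound 1 `CC1=C([Se]CC(OC(=O)CC[Se]c2ccccc2)C(=O)NCCCCCC(=O)OCc2ccccc2)C(=O)c2ccccc2C1=O`, 4000 nM
compound 2 `CC1=C(SCCC(=O)OC(C[Se]C2=C(C)C(=O)c3ccccc3C2=O)C(=O)NC(C)(C)C)C(=O)c2ccccc2C1=O`, 3000 nM

In a functional assay on A498 cells (Homo sapiens) for cytotoxicity, read by MTT assay, with a stated time of 24 h (a higher number here means a weaker inhibitor, a lower number a stronger inhibitor), compound 1 gives 4000 nM, the higher of the two numbers recorded so far. Compound 2 gives 3000 nM in this assay, and the gap between the two lies within the scatter, so neither can be called the stronger or weaker of the pair.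

Compound 3 `CC1=C([Se]CC(OC(=O)[C@@H](CO)NC(=O)OC(C)(C)C)C(=O)NCCCCCC(=O)OCc2ccccc2)C(=O)c2ccccc2C1=O` has not yet been measured in this assay. It differs from compound 1 in one place: a group of 11 heavy atoms (7 carbon, 1 nitrogen, 3 oxygen; no ring) in place of a group of 9 heavy atoms (8 carbon, 1 selenium; one six-membered aromatic ring of carbon only), on a carbonyl carbon

For the measured compounds named here, no step between two measured compounds is known, so there is nothing to lean on for the size of this change. Because compound 1 sits at 4000 nM in this assay, compound 3 is expected to land near that value, with a modest shift toward a higher number that may not exceed the scatter, giving a step of a 1.5-fold higher number from compound 1 to compound 3 (0.18 log units; within the scatter). Compound 3 is thus estimated at 6000 nM in this assay, within a range from 2500 nM to 15000 nM.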

Compound 3, half-maximal inhibitory concentration: 5000 nM
The estimate for compound 3 lay 1.2-fold (0.08 log units) above the measured number; the measured number falls inside the stated range.
By their numbers in this assay, from the lowest: compounds 2, 1 and 3 (each within the scatter of the next).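

At this carbonyl carbon, the selenium-containing group with its six-membered aromatic ring can be replaced by 2-hydroxy-1-((tert-butoxycarbonyl)amino)ethyl, and this assay records a 1.3-fold higher number from compound 1 to compound 3 (0.10 log units; within the scatter). This pair therefore shows that a group with no selenium and no ring, carrying hydrogen-bond donors and acceptors where the old group had none, gives a number that cannot be told apart from the original. Nothing measured here explains why two such different groups read alike.

The compounds shown leave open whether a free amine in place of the tert-butoxycarbonyl-protected one would also read the same at this carbonyl carbon. They also leave open what a methyl group in place of the hydroxymethyl arm, or the opposite arrangement at the new stereocentre, would do to the number.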